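Replacing nitro with hydroxy in compound 3

A few compounds are considered here, and "the series" means these few. Any claim that something is new, unique, unknown or untested is made for them only; others in the source may bear on it.

compound 1 `COc1ccc(C2OC(c3ccc4ccccc4c3)=NN2C(C)=O)cc1`: 3.6 ug/mL
compound 2 `CC(=O)N1N=C(c2ccc3ccccc3c2)OC1c1ccc(Br)cc1`: 2.08 ug/mL
compound 3 `CC(=O)N1N=C(c2ccc3ccccc3c2)OC1c1ccccc1[N+](=O)[O-]`: 12.3 ug/mL

All three values come from a functional assay on HepG2 cells (Homo sapiens) for antiproliferative activity, read by MTT assay, with a stated time of 48 h; on this read-out lower numbers stand for stronger inhibition and higher numbers for weaker inhibition. Compound 3, at 12.3 ug/mL, has the highest number of the three, which makes it the weakest inhibitor so far. The next compound, compound 4 `CC(=O)N1N=C(c2ccc3ccccc3c2)OC1c1ccccc1O`, keeps the shared core and carries hydroxy in place of nitro on an aromatic carbon. Going by the values given here, no measured step makes this exact swap, so the evidence is indirect. Two modest steps reach the 2-nitrophenyl group: a 3.4-fold higher number from compound 1 to compound 3 (0.53 log units; beyond the scatter) and a 5.9-fold higher number from compound 2 to compound 3 (0.77 log units; beyond the scatter). By contrast, a 1.7-fold lower number from compound 1 to compound 2 (0.24 log units; within the scatter), so only the 2-nitrophenyl compound stands apart. Leaving nitro may therefore bring the number back towards the other two, although hydroxy itself is untested and the direction remains uncertain. The expected change is a modest drop, a 2.1-fold lower number from compound 3 to compound 4 (0.31 log units; beyond the scatter). Compound 4 is estimated at 6 ug/mL, with an expected range from 2 ug/mL to 16 ug/mL.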

Compound 4, half-maximal inhibitory concentration: 1.84 ug/mL
Compound 4: the middle estimate sits 3.3-fold (0.51 log units) above what was measured; measured number below the stated range.
By their numbers in this assay, from the lowest: compounds 4, 2 and 1 (each within the scatter of the next); then compound 3.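

In this assay, going by these compounds alone, hydroxy in place of nitro on this aromatic carbon, ortho to a large group, gives a 6.7-fold lower number from compound 3 to compound 4 (0.83 log units; beyond the scatter), the first direct reading of this swap. The high number of compound 3 therefore does not come from simply having a group at this place, as compound 4 carries one there too; among these compounds, the difference follows the nitro group. The 2-hydroxyphenyl group also cannot be told apart from the 4-bromophenyl or 4-methoxyphenyl groups, with a 1.1-fold lower number from compound 2 to compound 4 (0.05 log units; within the scatter) and a 2.0-fold lower number from compound 1 to compound 4 (0.29 log units; within the scatter), and no measurement on hand explains why nitro and hydroxy differ.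

Going by these compounds, whether an amine or a carboxylic acid on this same carbon would stay with compound 4 or move towards compound 3 remains open. So does whether hydroxy or nitro would give the same numbers on another carbon of this ring.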